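The source may hold more compounds than are shown below. What is called first, only, known or untested is meant among the compounds shown, and "the series" means these compounds.

Compound 1 `COc1cc2ncnc(Nc3ccc(F)c(Cl)c3)c2cc1NC(=O)N/N=C/c1ccc(F)cc1` and compound 2 `COc1ccc(/C=N/NC(=O)Nc2cc3c(Nc4ccc(F)c(Cl)c4)ncnc3cc2OC)cc1` share one core and differ only in the aryl tail of the acylhydrazone. In a functional assay on PC-3 cells (Homo sapiens) for cytotoxicity, read by MTT assay, with a stated time of 72 h (a lower number here means a stronger inhibitor, a higher number a weaker inhibitor), compound 1 gives 36500 nM and compound 2 gives 16500 nM, the lowest of the two numbers. The step of a 2.2-fold lower number from compound 1 to compound 2 (0.34 log units; beyond the scatter) is modest but beyond the scatter. Compound 3 `COc1cc2ncnc(Nc3ccc(F)c(Cl)c3)c2cc1NC(=O)N/N=C/c1ccc(O)c(Br)c1` carries 3-bromo-4-hydroxyphenyl in place of 4-methoxyphenyl on a carbon with a double bond to nitrogen. Among the compounds with values here, no measured step covers this change; the single step available shows only that the aryl tail moves the number modestly. A step of similar size, a 1.2-fold lower number from compound 2 to compound 3 (0.07 log units; within the scatter), is therefore expected. For compound 3 in this assay the estimate is 14000 nM, range 5000 nM to 40000 nM.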

Compound 3, half-maximal inhibitory concentration: 15300 nM
Estimate against measurement, compound 3: 1.1-fold (0.04 log units) below; measured number inside the range.
By their numbers in this assay, from the lowest: compounds 3 and 2 (each within the scatter of the next); then compound 1.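

In this assay the step of a 1.1-fold lower number from compound 2 to compound 3 (0.03 log units; within the scatter) shows that 3-bromo-4-hydroxyphenyl on a carbon with a double bond to nitrogen reads level with 4-methoxyphenyl, although it adds a hydrogen-bond donor and a bromine. The step of a 2.4-fold lower number from compound 1 to compound 3 (0.38 log units; beyond the scatter) sets it apart from 4-fluorophenyl by a modest margin, as 4-methoxyphenyl already was. No evidence on hand explains these readings. The compounds shown do not separate the contribution of the bromine from that of the hydroxyl. Going by these compounds, how an aryl tail bearing an amine or a carboxylic acid would read also stays open.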